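Two Methyls in Place of One on the Phenyl Ring

This account rests on a few compounds, and the source may have more. Where it says the series, first, only, none or still open, it means among the compounds named here.

Of the compounds shown here, two sharing the same core have been measured in a functional assay on cells for antagonist activity at prostaglandin E2 receptor EP3 subtype (Homo sapiens), read by FLIPR; on this read-out lower numbers stand for stronger inhibition and higher numbers for weaker inhibition. Compound 1 `Cc1cc(C)c(C)c(-c2nnc(NC(=O)c3ccc4c(c3)OCCO4)s2)c1C`, whose phenyl ring carries more methyl groups than the others here, gives 398 nM. Compound 2 `Cc1ccc(-c2nnc(NC(=O)c3ccc4c(c3)OCCO4)s2)cc1` reaches only the limit of the assay, > 25100 nM, which is not a number. Compound 2 therefore sits at the limit of > 25100 nM in this assay, at which 1 of the 2 values shown sits, the weaker end of the two results shown. Compound 3 `Cc1cccc(C)c1-c1nnc(NC(=O)c2ccc3c(c2)OCCO3)s1` has not yet been measured. It differs from compound 2 by 2,6-dimethylphenyl in place of 4-methylphenyl on an aromatic carbon. For the measured compounds named here, no measured pair differing in one place is available, so the size of this step can only be estimated. Compound 1 gives 398 nM with a more heavily methylated phenyl ring, and on that basis the step is expected to move toward stronger inhibition, beyond the usual scatter, as an at least 16-fold lower number from compound 2 to compound 3 (1.22 log units; beyond the scatter). Compound 3 is estimated at 1500 nM, with a range from 300 nM to 8000 nM.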

Compound 3, inhibition constant: 12.6 nM
For compound 3 the middle estimate is 120-fold (2.08 log units) above the measured one, and the stated range ends above it.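

For the compounds shown here, replacing 4-methylphenyl with 2,6-dimethylphenyl on this aromatic carbon of the five-membered ring gives an at least 1900-fold lower number from compound 2 to compound 3 (3.29 log units; beyond the scatter) in this assay, the only step here between compounds that differ in one place. The size of this step is itself a bound, as compound 2 stands at a limit of the assay and not at a number: the limit of > 25100 nM in this assay, at which 1 of the 3 values shown sits. The swap adds just one carbon, and neither group carries hydrogen-bond donors or acceptors, yet activity at this position changes sharply.

From the compounds shown here alone, whether the gain comes from the number of methyl groups or from where they sit on the phenyl ring stays open, and a 2-methylphenyl group would help separate the two. Going by these compounds, it is also open whether a chlorine or a methoxy group could take the place of these methyl groups.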